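Swapping One Arm of Compound 2: Expecting Compound 3

A few compounds are considered here, and "the series" means these few. Any claim that something is new, unique, unknown or untested is made for them only; others in the source may bear on it.

Compound 1 `O=C(Nc1cccc(-n2cc(-c3ccncc3)c(-c3cc(O)cc(Cl)c3)n2)c1)Nc1ccc(Cl)c(Cl)c1` gives 99% in a functional assay on M14 cells (Homo sapiens) for inhibition, read by sulforhodamine B assay, with a stated time of 48 h, tested at 0.01 uM; on this read-out higher numbers stand for a weaker effect at the one concentration tested and lower numbers for a stronger effect.
Compound 2 `COc1cc(Cl)cc(-c2nn(-c3cccc(NC(=O)Nc4ccc(Cl)c(Cl)c4)c3)cc2-c2ccncc2)c1` gives 97% in this assay.

Going by the values given here, only two compounds have been measured, and the step of a number 2 percentage points lower from compound 1 to compound 2 (within the scatter) shows that methyl in place of hydrogen on an oxygen on an aromatic ring made no difference beyond the scatter. Compound 2 stands as the lowest of the two numbers, with compound 1 the nearest, though within the scatter of it, so the two read as the same weak effect at this concentration.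

Compound 3 `COc1cc(Cl)cc(-c2nn(-c3cccc(NC(=O)c4cccc(C(F)(F)F)c4)c3)cc2-c2ccncc2)c1` differs from compound 2 by 3-(trifluoromethyl)phenyl in place of (3,4-dichlorophenyl)amino on a carbonyl carbon. Among the compounds with values here, no measured step touches this part of the structure: the one step known concerns the oxygen on the other aromatic ring. Within the data shown here, there is therefore no precedent pointing in either direction. With the shared core unchanged, compound 3 is estimated to stay near compound 2, at 94% within 78% to 105%, a step of a number 3 percentage points lower from compound 2 to compound 3 (within the scatter) that is expected to lie within the scatter.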

Compound 3, a percentage reported as activity, at one concentration (the size of the read-out at that concentration, not a potency): 101%
For compound 3 the middle estimate is 7 percentage points below the measured one, within the range that was stated.
By their numbers in this assay, from the lowest: compounds 2, 1 and 3 (each within the scatter of the next).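

Going by these compounds alone, this is the first look at the carbonyl end of the molecule: putting 3-(trifluoromethyl)phenyl in place of (3,4-dichlorophenyl)amino on a carbonyl carbon gives a number 4 percentage points higher from compound 2 to compound 3 (within the scatter) in this assay and so does not change the read-out beyond the scatter. The swap removes the amino nitrogen with its hydrogen-bond donor and both chlorines, and brings in three fluorines, yet at this one low concentration the weak effect stays the same. No outside evidence bears on this result.

Because all the compounds here read as equally weak, this single concentration cannot show whether the group on the carbonyl carbon matters at all. As far as these compounds go, it remains open how a morpholine, a carboxylic acid or a plain butyl chain on that carbonyl carbon would read.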